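The source may hold more compounds than are shown below. What is called first, only, known or untested is meant among the compounds shown, and "the series" means these compounds.

Measured in a functional assay on BT-549 cells (Homo sapiens) for inhibition, read by sulforhodamine B assay, with a stated time of 6 days; a lower number here means a stronger inhibitor, a higher number a weaker inhibitor:
- Compound 1 `CNCCNCc1cccc(-c2nc(NC3CCOCC3)c(C)c(-c3cn(C)nc3C)n2)c1`: > 50000 nM (a limit)
- Compound 2 `CNCCNCc1cccc(-c2nc(Nc3ccccc3)c(C)c(-c3c(C)nn(C)c3C)n2)c1`: 8200 nM
- Compound 3 `CNCCNCc1cccc(-c2nc(NC3CCOCC3)c(C)c(-c3c(C)nn(C)c3C)n2)c1`: > 50000 nM (a limit)

Compound 1 has no number in this assay, only the limit > 50000 nM. The move to compound 4 `CNCCNCc1cccc(-c2nc(NC3CCOCC3)c(C)c(-c3ccnn3C)n2)c1` is 1-methyl-1H-pyrazol-5-yl in place of 1,3-dimethyl-1H-pyrazol-4-yl on an aromatic carbon, next to the ring nitrogen and ortho to a methyl group. Within the data shown here, the one measured change on this group, a step that the two limits leave unreadable from compound 1 to compound 3, gives no size to carry over. Among the measured compounds shown here, the only readable step, an at least 6.0-fold higher number from compound 2 to compound 3 (0.78 log units; beyond the scatter), concerns oxan-4-yl in place of phenyl, and compound 4 keeps the (oxan-4-yl)amino group. No gain in strength is therefore expected, since compound 1 and compound 3 both carry that group and sit at the limit of > 50000 nM in this assay, at which 2 of the 3 values shown sit. The expected outcome, a number no higher from compound 1 to compound 4 (the limit leaves the size open), is an estimate, and no step beyond the scatter is expected. For compound 4 the estimated value is 50000 nM, with an expected range from 20000 nM to 100000 nM.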

Compound 4, half-maximal inhibitory concentration: > 50000 nM
Compound 4 ended at the assay's limit; the forecaster's own chance of this, stated with the estimate: 80%; the middle value lies on the limit itself.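

In this assay compound 4 gives > 50000 nM, a limit and not a number. The steps to compound 4 from compound 1 and compound 3 cannot be read, because all three compounds stand at a limit: the limit of > 50000 nM in this assay, at which 3 of the 4 values shown sit.

The compounds shown leave open whether 1-methyl-1H-pyrazol-5-yl and 1,3-dimethyl-1H-pyrazol-4-yl differ at all in strength of inhibition.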